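The compounds below may be only part of what the source reports. "The series", "measured", "known", "first", "only" and "open" are said of these compounds alone.

Measured so far in a physicochemical assay for solubility; on this read-out lower numbers stand for lower solubility and higher numbers for higher solubility:
compound 1, `O=C(O)c1ccc(C(=O)/C(=C\c2ccc(F)c([N+](=O)[O-])c2)SCc2ccc(Cl)cc2Cl)cc1`, < 1000 ug/mL
compound 2, `COc1cc(/C=C(/SCc2ccc(Br)cc2)C(=O)c2ccc(C(=O)O)cc2)ccc1F`, < 1000 ug/mL

Both readings are limits of this assay, not numbers. On these data alone, compound 2 stands at the limit of < 1000 ug/mL in this assay, at which 2 of the 2 values shown sit, so its true solubility is unknown beyond that bound.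

Compound 3, `O=C(O)c1ccc(C(=O)/C(=C\c2ccc(Br)c([N+](=O)[O-])c2)SCc2ccc(Br)cc2)cc1`, remains unmeasured. The change from compound 2: 4-bromo-3-nitrophenyl in place of 4-fluoro-3-methoxyphenyl on a double-bonded chain carbon bound to a double-bonded chain carbon.

Among the compounds with values here, no measured step is available. The expected step in this assay, a step that the limit leaves unreadable from compound 2 to compound 3, is none beyond the scatter. Compound 3 is estimated at 300 ug/mL, in the range 30 ug/mL to 1000 ug/mL, and most likely reported again only as a limit.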

Compound 3, solubility: < 1000 ug/mL
Compound 3 was reported as a limit (the forecaster's own chance of this, stated with the estimate: 80%); the middle value does not contradict the limit.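

No step can be read from compound 2 to compound 3 in this assay, because both readings are limits: the limit of < 1000 ug/mL in this assay, at which 3 of the 3 values shown sit.

The compounds shown leave open the actual solubility of compound 1, compound 2 and compound 3, and whether 4-bromo-3-nitrophenyl in place of 4-fluoro-3-methoxyphenyl changes it at all.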